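Swapping a chloropyrazinyl amide for an imidazolyl amide

This account rests on a few compounds, and the source may have more. Where it says the series, first, only, none or still open, it means among the compounds named here.

Three compounds share a core bearing an amide. In an ADME assay on Vero cells (Chlorocebus sabaeus) for cytotoxicity (on this read-out higher numbers stand for lower toxicity in this test and lower numbers for higher toxicity in this test), compound 1 `COc1ccc(-c2nc3c(C(=O)Nc4ccccc4F)cccc3[nH]2)cc1OC` gives 24.5 uM, compound 2 `CCC(CC)NC(=O)c1cccc2[nH]c(-c3ccc(OC)c(OC)c3)nc12` gives 2.23 uM, and compound 3 `COc1ccc(-c2nc3c(C(=O)Nc4cnc(Cl)cn4)cccc3[nH]2)cc1OC` gives 78.3 uM, the highest of the three numbers. The steps read an 11-fold lower number from compound 1 to compound 2 (1.04 log units; beyond the scatter), a 3.2-fold higher number from compound 1 to compound 3 (0.50 log units; beyond the scatter) and a 35-fold higher number from compound 2 to compound 3 (1.55 log units; beyond the scatter). Compound 4 `COc1ccc(-c2nc3c(C(=O)Nc4c[nH]cn4)cccc3[nH]2)cc1OC` differs from compound 3 by 1H-imidazol-4-yl in place of 5-chloropyrazin-2-yl on an amide-type nitrogen. Only a 3.2-fold higher number from compound 1 to compound 3 (0.50 log units; beyond the scatter) exchanges one aromatic group for another at this nitrogen, and it was modest; the large 35-fold higher number from compound 2 to compound 3 (1.55 log units; beyond the scatter) concerns a chain replaced by a ring, and compound 4 keeps a ring. A step of modest size, probably downward, is therefore expected in this assay. Compound 4 is estimated at 40 uM, within 12 uM to 130 uM, an expected step of a 2.0-fold lower number from compound 3 to compound 4 (0.29 log units; within the scatter).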

Compound 4, half-maximal toxic concentration: 306 uM
For compound 4 the middle estimate is 7.7-fold (0.88 log units) below the measured one, and the stated range ends below it.
By their numbers in this assay, from the lowest: compound 2; then compound 1; then compound 3; then compound 4.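

In this assay the exchange of one aromatic group for another at this amide-type nitrogen went upward, with a 3.9-fold higher number from compound 3 to compound 4 (0.59 log units; beyond the scatter) in place of the modest fall expected. The 1H-imidazol-4-yl group also gives a 12-fold higher number from compound 1 to compound 4 (1.10 log units; beyond the scatter) and a 140-fold higher number from compound 2 to compound 4 (2.14 log units; beyond the scatter), so compound 4 holds the highest number of the four, beyond the scatter from each of the others. Nothing at hand explains this rise.

On these data alone, compound 3 and compound 4 differ in ring size, hydrogen-bond donor count and chlorine all at once, so which of these carries the step stays open. A pyrazinyl amide without the chlorine, or a methylimidazolyl amide, would begin to separate them.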